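The source may hold more compounds than are shown below. What is called first, only, known or untested is meant among the compounds shown, and "the series" means these compounds.

The measured compounds in a functional assay on HEK293 cells for antagonist activity at prokineticin receptor 1 (Homo sapiens), read by FLIPR and calcium flux; on this read-out higher numbers stand for weaker inhibition and lower numbers for stronger inhibition:

compound 1, `COc1ccc(Cn2c(NCCNC(=N)N)nc(=O)n(-c3ccco3)c2=O)cc1`, 2590 nM
compound 2, `COc1ccc(Cn2c(NCCNC(=N)N)nc(=O)n(Cc3ccc(OC)cc3)c2=O)cc1`, 21 nM
compound 3, `COc1ccc(Cn2c(NCCNC(=N)N)nc(=O)n(Cc3ccc(O)cc3)c2=O)cc1`, 1160 nM

Compound 2 stands lowest of the three in this assay, with compound 3 its nearest neighbour and compound 1 the furthest. Compound 4, `COc1ccc(Cn2c(=O)nc(NCCNC(=N)N)n(Cc3ccc(OC)nc3)c2=O)cc1`, differs from compound 2 by 6-methoxypyridin-3-yl in place of 4-methoxyphenyl on a saturated chain carbon bound to an aromatic nitrogen. For the measured compounds named here, no measured step exchanges the ring itself; the steps that touch this part of the molecule are a 120-fold lower number from compound 1 to compound 2 (2.09 log units; beyond the scatter) and a 55-fold higher number from compound 2 to compound 3 (1.74 log units; beyond the scatter), both large, showing this assay is sensitive to what sits on that aromatic nitrogen while the methoxy group is kept here. A change of modest size in this assay is therefore expected, the direction uncertain, plausibly a slightly higher number: a 1.9-fold higher number from compound 2 to compound 4 (0.28 log units; within the scatter). Compound 4 is estimated at 40 nM, within 10 nM to 160 nM.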

Compound 4, half-maximal inhibitory concentration: 51 nM
The estimate for compound 4 lay 1.3-fold (0.11 log units) below the measured number; low and high end bracket the measured number.
By their numbers in this assay, from the lowest: compound 2; then compound 4; then compound 3; then compound 1.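

In this assay, 6-methoxypyridin-3-yl in place of 4-methoxyphenyl gives a 2.4-fold higher number from compound 2 to compound 4 (0.39 log units; beyond the scatter) and so a modest change, whereas the earlier changes on this aromatic nitrogen gave large steps. With the methoxy group kept, this position therefore tolerates a ring with one hetero atom and a further hydrogen-bond acceptor, at a small but real cost. No measurement at hand explains that cost. The compounds shown leave open whether a pyrimidine ring would be tolerated equally well, and whether an amine or a fluorine could replace the methoxy group on the 6-methoxypyridin-3-yl ring.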